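Anilinoquinazoline-type series: 2-bromophenyl replacing 4-chlorophenyl

A few compounds are considered here, and "the series" means these few. Any claim that something is new, unique, unknown or untested is made for them only; others in the source may bear on it.

Measured so far in a functional assay on COLO 205 cells (Homo sapiens) for cytotoxicity, read by MTT assay, with a stated time of 48 h; a higher number here means a weaker inhibitor, a lower number a stronger inhibitor:
compound 1 `Fc1cccc(-c2nc(Nc3ccccc3)c3ccccc3n2)c1`: compound 1 gives > 50000 nM, a limit of the assay.
compound 2 `Fc1cccc(-c2nc(Nc3ccccc3F)c3cc(F)ccc3n2)c1`: compound 2 gives > 50000 nM, a limit of the assay.
compound 3 `Fc1cccc(-c2nc(Nc3ccc(Cl)cc3)c3cc(F)ccc3n2)c1`: compound 3 gives 32600 nM.

Going by the values given here, compound 3 is the only compound of the three with a number in this assay; the other two sit at the assay limit (the limit of > 50000 nM in this assay, at which 2 of the 3 values shown sit). Among the compounds with values here, the one step with a measurable size is an at least 1.5-fold lower number from compound 2 to compound 3 (0.18 log units; that floor lies within the scatter), and its floor lies within the scatter.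

Compound 4 `Fc1cccc(-c2nc(Nc3ccccc3Br)c3cc(F)ccc3n2)c1` is not yet measured. The change from compound 3 is 2-bromophenyl in place of 4-chlorophenyl on a nitrogen on an aromatic ring. Within the data shown here, the only step that bears on it runs the other way: it replaced a 2-fluorophenyl on that nitrogen, the pattern of compound 2, with 4-chlorophenyl, and gave an at least 1.5-fold lower number from compound 2 to compound 3 (0.18 log units; that floor lies within the scatter). Compound 4 returns to a 2-substituted phenyl on that nitrogen, so a number no better than compound 3, and quite possibly a return to the assay limit, is expected; the expected step is a 1.5-fold higher number from compound 3 to compound 4 (0.19 log units; within the scatter). For compound 4 the estimate in this assay is 50000 nM, within 25000 nM to 100000 nM.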

Compound 4, half-maximal inhibitory concentration: > 50000 nM
Compound 4 gave a limit, no number (the forecaster's own chance of this, stated with the estimate: 55%); the middle value sits exactly at the limit.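

In this assay compound 4 is a limit, not a number, and it joins the other compounds there: the limit of > 50000 nM in this assay, at which 3 of the 4 values shown sit. Going by these compounds alone, the change gives an at least 1.5-fold higher number from compound 3 to compound 4 (0.18 log units; that floor lies within the scatter), so no real loss against compound 3 can be claimed, although compound 3 remains the only compound with a number. The step from compound 2 to compound 4, bromo in place of fluoro on an aromatic carbon, cannot be read, since both values are limits, and it says nothing about the choice between these two halogens.

The change from 4-chlorophenyl to 2-bromophenyl alters both the halogen and its place on the phenyl, and the compounds shown do not separate the two. From the compounds shown here alone, whether an amine or a carboxylic acid on that phenyl would give a measurable number stays open.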